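Adding a ((chloromethyl)carbonyl)amino group to compound 3

The source may hold more compounds than are shown below. What is called first, only, known or untested is meant among the compounds shown, and "the series" means these compounds.

Of the compounds shown here, three so far sit at the same limit in a functional assay on MCF7 cells (Homo sapiens) for inhibition, read by MTT assay, with a stated time of 72 h; a higher number here means a weaker inhibitor, a lower number a stronger inhibitor. Compound 1 `Cn1cc(CO)c(N)nc1=O` gives > 100000 nM, which is a limit of the assay. Compound 2 `Cc1cc(=O)[nH]c(=O)n1COC(CO)CO` gives > 100000 nM, also a limit. Compound 3 `O=c1ccn(COC(CO)CO)c(=O)[nH]1` gives > 100000 nM, again a limit. The step from compound 2 to compound 3, a step that the two limits leave unreadable from compound 2 to compound 3, cannot be read because both ends sit at the limit of > 100000 nM in this assay, at which 3 of the 3 values shown sit. Compound 4 `O=C(CCl)Nc1cn(COC(CO)CO)c(=O)[nH]c1=O` differs from compound 3 by ((chloromethyl)carbonyl)amino in place of hydrogen on an aromatic carbon. Among the compounds with values here, no measured step bears on this change, and with every value a limit no direction can be drawn from the data. Compound 4 is therefore expected to stay near the limit, with an estimate of 100000 nM ranging from 30000 nM to 300000 nM. The step this estimate implies, a number no higher from compound 3 to compound 4 (the limit leaves the size open), is an expectation only.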

Compound 4, half-maximal inhibitory concentration: 32000 nM
Compound 4: the middle estimate sits 3.1-fold (0.49 log units) above what was measured; low and high end bracket the measured number.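

Putting ((chloromethyl)carbonyl)amino in place of hydrogen on this aromatic carbon, two atoms from the ring nitrogen, brings an at least 3.1-fold lower number from compound 3 to compound 4 (0.49 log units; beyond the scatter) in this assay. This is the first change shown that moves a compound off the limit, and compound 4 is the only compound here with a measured number. On these data alone, the full size of the step stays open, as one end is a limit: the limit of > 100000 nM in this assay, at which 3 of the 4 values shown sit. As far as these compounds go, whether a plain amine or an acetylamino group on the same carbon would do the same, without the chlorine, remains open.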